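Working notes: from a nitrile to a methoxy ring

A few compounds are considered here, and "the series" means these few. Any claim that something is new, unique, unknown or untested is made for them only; others in the source may bear on it.

In an ADME assay on microsomes from liver (Rattus norvegicus) for metabolic stability (on this read-out higher numbers stand for a longer-lived compound and lower numbers for a shorter-lived compound), compound 1 `COc1cc(OCc2csc(-c3ccc(C(F)(F)F)cc3)n2)c2cc(-c3cn4nc(OC)sc4n3)oc2c1` gives 1.42 h, compound 2 `COc1cc(OCc2cccc(-c3ccc(OC)nc3)c2)c2cc(-c3cn4nc(OC)sc4n3)oc2c1` gives 0.633 h and compound 3 `COc1cc(OCc2cccc(-c3ccc(C#N)cn3)c2)c2cc(-c3cn4nc(OC)sc4n3)oc2c1` gives 0.833 h. The number for compound 3 is the middle one of the three and lies within the scatter of the numbers for both other compounds.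

Compound 4 `COc1cc(OCc2cccc(-c3cnc(OC)cn3)c2)c2cc(-c3cn4nc(OC)sc4n3)oc2c1` has not yet been measured. It differs from compound 3 as follows: 5-methoxypyrazin-2-yl in place of 5-cyanopyridin-2-yl on an aromatic carbon. In words, 5-methoxypyrazin-2-yl stands in place of 5-cyanopyridin-2-yl on an aromatic carbon of a six-membered aromatic ring of carbon only, meta to a large group.

Among the measured compounds shown here, one measured step bears on this change: a 1.3-fold higher number from compound 2 to compound 3 (0.12 log units; within the scatter). That step exchanges 6-methoxypyridin-3-yl for 5-cyanopyridin-2-yl at the same place and stays within the scatter. For the measured compounds named here, no measured compound carries 5-methoxypyrazin-2-yl, so the evidence is indirect. The closest comparison is compound 2, which also has a methoxy group on its six-membered aromatic ring and gives 0.633 h.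

In this assay, the expected change is small, and a 1.2-fold lower number from compound 3 to compound 4 (0.06 log units; within the scatter) is estimated to stay within the scatter, with no firm direction. For compound 4 the estimated value is 0.72 h, with an expected range from 0.4 h to 1.3 h.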

Compound 4, half-life: 1.62 h
The estimate for compound 4 lay 2.3-fold (0.35 log units) below the measured number; the measured number lies above the stated range.
By their numbers in this assay, from the lowest: compounds 2, 3, 1 and 4 (each within the scatter of the next, the first and the last beyond it).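

In this assay, among the compounds shown here, the place on the six-membered aromatic ring of carbon only, meta to a large group, now gives a step beyond the scatter: 5-methoxypyrazin-2-yl in place of 6-methoxypyridin-3-yl gives a 2.6-fold higher number from compound 2 to compound 4 (0.41 log units; beyond the scatter), a modest step, whereas the only earlier step at this place stayed within the scatter. Against 5-cyanopyridin-2-yl, the same group gives a 1.9-fold higher number from compound 3 to compound 4 (0.29 log units; within the scatter), so compound 4 cannot be separated from compound 3 on this read-out, and the series offers no clear ranking of the nitrile ring against the new ring. Compound 2 and compound 4 both carry a methoxy group on the ring at this place, yet their numbers differ beyond the scatter, so the presence of a methoxy group alone does not fix the half-life in these compounds.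

Going by these compounds, it remains open whether an amine or a carboxylic acid in place of the methoxy group on the 5-methoxypyrazin-2-yl ring would keep the number of compound 4. No measurement shown here accounts for the step from compound 2 to compound 4.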